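This account rests on a few compounds, and the source may have more. Where it says the series, first, only, none or still open, it means among the compounds named here.

Of the compounds shown here, three built on one shared core have been tested in an ADME assay on MT4 cells (Homo sapiens) for cytotoxicity, read by MTT assay; a lower number here means that less compound is tolerated, a higher number that more compound is tolerated. Compound 1 `Cc1cc(C)cc(S(=O)(=O)c2c(C(=O)NCC(=O)NC(C)c3ccccc3)[nH]c3ccc(Cl)cc23)c1` gives 29400 nM. Compound 2 `Cc1cc(C)cc(S(=O)(=O)c2c(C(=O)NC(C)C(=O)NCc3ccco3)[nH]c3ccc(Cl)cc23)c1` gives 24200 nM. Compound 3 `Cc1cc(C)cc(S(=O)(=O)c2c(C(=O)NCC(=O)NCc3ccco3)[nH]c3ccc(Cl)cc23)c1` reaches only a limit of the assay, > 50000 nM, and that limit is the limit of > 50000 nM in this assay, at which 1 of the 3 values shown sits.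

Two changes connect these compounds. From compound 3 to compound 1 the change is 1-phenylethyl in place of (furan-2-yl)methyl on an amide-type nitrogen and the number moves by an at least 1.7-fold lower number from compound 3 to compound 1 (0.23 log units; that floor lies within the scatter). From compound 3 to compound 2 the cores differ by methyl in place of hydrogen on a saturated chain carbon bound to an amide-type nitrogen and a carbonyl carbon, and the measured step runs an at least 2.0-fold higher number from compound 2 to compound 3 (0.31 log units; beyond the scatter). Compound 1 and compound 2 sit close together, a 1.2-fold lower number from compound 1 to compound 2 (0.08 log units; within the scatter).

Compound 4 `Cc1cc(C)cc(S(=O)(=O)c2c(C(=O)NC(C)C(=O)NC(C)c3ccccc3)[nH]c3ccc(Cl)cc23)c1` has not yet been measured. It differs from compound 2 by 1-phenylethyl in place of (furan-2-yl)methyl on an amide-type nitrogen. The place line reads the same word for word as in the change from compound 3 to compound 1, so this is the same change made on the other core. Since the earlier step from compound 3 to compound 1 moved the number downward, and since compound 2 starts from a measured value of 24200 nM, the number for compound 4 is expected to fall by about a 1.5-fold lower number from compound 2 to compound 4 (0.18 log units; within the scatter). Compound 4 is therefore estimated at 16000 nM, with a likely range from 7000 nM to 35000 nM.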

Compound 4, half-maximal cytotoxic concentration: 21700 nM
The estimate for compound 4 lay 1.4-fold (0.13 log units) below the measured number; low and high end bracket the measured number.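

In this assay, putting 1-phenylethyl in place of (furan-2-yl)methyl on the amide-type nitrogen gives a 1.1-fold lower number from compound 2 to compound 4 (0.05 log units; within the scatter), and putting methyl in place of hydrogen on the saturated chain carbon gives a 1.4-fold lower number from compound 1 to compound 4 (0.13 log units; within the scatter), so neither new step stands out from the scatter. Both changes also connect to compound 3, whose value is a limit and not a number, so the earlier step for the 1-phenylethyl change is only a floor, and the data do not show whether this change carries over unchanged in size or behaves differently on the second core: the same change on two cores in this assay, an at least 1.7-fold lower number (0.23 log units; that floor lies within the scatter) from compound 3 to compound 1 and a 1.1-fold lower number (0.05 log units; within the scatter) from compound 2 to compound 4; the limit leaves it open whether they differ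
The methyl change is in the same position, for although its earlier step lies beyond the scatter and its new step within it, this does not establish a real difference between the two cores: the same change on two cores in this assay, an at least 2.0-fold higher number (0.31 log units; beyond the scatter) from compound 2 to compound 3 and a 1.4-fold higher number (0.13 log units; within the scatter) from compound 4 to compound 1; the limit leaves it open whether they differ

The compounds shown leave open how the number responds to an ethyl group or a longer chain in place of that methyl, and to a benzyl group or a pyridine ring on the amide-type nitrogen. They also leave open whether either change behaves the same way on a core carrying a different group in place of the chlorine.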